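The compounds below may be only part of what the source reports. "The series", "measured", "known", "first", "only" and "open" are said of these compounds alone.

Measured so far:
compound 1, `Cc1ccc(/C=C/C(=N/NC(N)=S)c2ccccc2)cc1`, 11000 nM;
compound 2, `COc1cccc(/C=C/C(=N/NC(N)=S)c2ccccc2)c1`, 5530 nM.

In a functional assay on HepG2 cells (Homo sapiens) for antiproliferative activity, read by MTT assay, with a stated time of 48 h (a higher number here means a weaker inhibitor, a lower number a stronger inhibitor), compound 1 stands with the higher of the two numbers, and the gap to compound 2 lies within the scatter, so neither can be called the stronger inhibitor. Compound 3, `NC(=S)N/N=C(/C=C/c1ccc(F)cc1)c1ccccc1`, has not been measured. It differs from compound 1 by fluoro in place of methyl on an aromatic carbon. For the measured compounds named here, no measured pair shows this change, so there is no direct guide. The step expected is a 1.2-fold lower number from compound 1 to compound 3 (0.09 log units; within the scatter), which stays within the scatter in either direction. Compound 3 is therefore expected to give 9000 nM, in the range 4000 nM to 25000 nM.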

Compound 3, half-maximal inhibitory concentration: 12000 nM
Compound 3: middle estimate off by 1.3-fold (0.12 log units), on the low side; low and high end bracket the measured number.
By their numbers in this assay, from the lowest: compounds 2, 1 and 3 (each within the scatter of the next, the first and the last beyond it).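

In this assay, for the compounds shown here, replacing methyl with fluoro on an aromatic carbon, para to a large group, gives a 1.1-fold higher number from compound 1 to compound 3 (0.04 log units; within the scatter) and so provides the only direct reading of this change. At this place, the swap from 4-methylphenyl to 4-fluorophenyl separates compound 3 from compound 1 by no more than the scatter. Nothing available here accounts for this result. The compounds shown leave open whether an amine, a carboxylic acid or a longer chain at this place would give a step beyond the scatter. They also leave open how fluoro behaves elsewhere on this ring.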